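A few compounds are considered here, and "the series" means these few. Any claim that something is new, unique, unknown or untested is made for them only; others in the source may bear on it.

Values measured in a functional assay on SGC-7901 cells (Homo sapiens) for antiproliferative activity, read by MTT assay, with a stated time of 24 h (on this read-out higher numbers stand for weaker inhibition and lower numbers for stronger inhibition), so far:
- compound 1 `Cc1cccc(NNC(=O)c2ccc(NS(=O)(=O)c3cnc(O)nc3O)cc2)c1` gives > 20000 nM (a limit of the assay)
- compound 2 `O=C(NNc1ccc(F)cc1)c1cccc(NS(=O)(=O)c2cnc(O)nc2O)c1` gives > 20000 nM (a limit of the assay)
- compound 3 `O=C(NNc1cccc(Cl)c1)c1ccccc1NS(=O)(=O)c1cnc(O)nc1O` gives 10800 nM (a number)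

Compound 2 stands at > 20000 nM as a limit and not a number. This is the limit of > 20000 nM in this assay, at which 2 of the 3 values shown sit, and compound 1 shares it. Compound 3 at 10800 nM is the only one of the three with a number.

The next compound is compound 4 `O=C(NNC(=O)c1cccc(NS(=O)(=O)c2cnc(O)nc2O)c1)c1ccc(F)cc1` and it carries (4-fluorophenyl)carbonyl in place of 4-fluorophenyl on an amine nitrogen. The counted difference from compound 2 is (4-fluorophenyl)carbonyl in place of 4-fluorophenyl on an amine nitrogen and the change is the same as (4-fluorophenyl)amino to ((4-fluorophenyl)carbonyl)amino.

For the measured compounds named here, no two measured compounds differ in one place, so no measured step sizes this change. The expectation in this assay therefore rests on the limit of > 20000 nM in this assay, at which 2 of the 3 values shown sit, and foresees no shift beyond the scatter in either direction. The expected at least 1.1-fold lower number from compound 2 to compound 4 (0.04 log units; that floor lies within the scatter) is accordingly small and only an estimate. Compound 4 is estimated at 18000 nM in this assay. The expected range for compound 4 runs from 7000 nM to 40000 nM as an estimate.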

Compound 4, half-maximal inhibitory concentration: > 20000 nM
Compound 4: a limit, no number; the forecaster's own chance of this, stated with the estimate: 55%; at least 1.1-fold (0.04 log units) between middle value and limit.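

In this assay compound 4 gives > 20000 nM, a limit and not a number. Compound 2 also stands at a limit, so no step can be read between compound 2 and compound 4: the limit of > 20000 nM in this assay, at which 3 of the 4 values shown sit.

The compounds shown leave open whether (4-fluorophenyl)carbonyl in place of 4-fluorophenyl on an amine nitrogen shifts antiproliferative activity in either direction.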